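The compounds below may be only part of what the source reports. "The series", "measured", "known", "first", "only" and "open" are said of these compounds alone.

Compound 1 `COc1cc(O)c(C=O)c2c1[C@H](O)C[C@@H](c1ccccc1)O2` gives 24300 nM in a functional assay on MOLT-3 cells (Homo sapiens) for cytotoxicity, read by XTT assay; a lower number here means a stronger inhibitor, a higher number a weaker inhibitor.
Compound 2 `COc1c(C)c(OC)c2c(c1C=O)O[C@H](c1ccccc1)C[C@H]2O` gives 57400 nM in this assay.
Compound 3 `COc1cc(O)c(C=O)c2c1[C@H](OC)C[C@@H](c1ccccc1)O2` gives 41300 nM in this assay.

Compound 1 carries the lowest number of the three, though compound 3 sits within the usual scatter of it, so the two cannot be told apart on these readings; compound 2 lies beyond the scatter of compound 1, and its number is the highest shown. The unmeasured compound 4 `COc1c(C)c(O)c(C=O)c2c1[C@H](O)C[C@@H](c1ccccc1)O2` differs from compound 1 in one place: methyl in place of hydrogen on an aromatic carbon.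

For the measured compounds named here, only one measured step is available, and it concerns a different site, since a 1.7-fold higher number from compound 1 to compound 3 (0.23 log units; within the scatter). That step was small and stayed within the scatter. Going by the values given here, no measured pair shows the effect of a methyl on an aromatic carbon alone; compound 2 has such a methyl but differs from compound 1 in several places at once, so its higher number cannot be attributed to the methyl. The shared core of compound 1 therefore appears to tolerate small additions without a clear shift, and a modest change, in either direction or none beyond the scatter, is the reasonable expectation in this assay.

On that basis compound 4 is expected to give 30000 nM, with a likely range from 12000 nM to 75000 nM, meaning an expected step of a 1.2-fold higher number from compound 1 to compound 4 (0.09 log units; within the scatter).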

Compound 4, half-maximal inhibitory concentration: 29800 nM
For compound 4 the middle estimate is 1.0-fold (0.00 log units) above the measured one, and the stated range covers the measured number.
By their numbers in this assay, from the lowest: compounds 1, 4, 3 and 2 (each within the scatter of the next, the first and the last beyond it).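

For the compounds shown here, the methyl on the aromatic carbon, ortho to a hydroxy group and ortho to a methoxy group, can now be read on its own for the first time: in this assay the change gives a 1.2-fold higher number from compound 1 to compound 4 (0.09 log units; within the scatter), so this position accepts the methyl with no shift that can be told from the scatter. With that methyl in place, the swap on the oxygen on the aromatic ring gives a 1.9-fold lower number from compound 2 to compound 4 (0.28 log units; within the scatter), which is also within the scatter. Going by these compounds alone, compound 4 thus lies within the scatter of both neighbours, although compound 1 and compound 2 lie beyond it from each other, so the gap between those two appears only when the single changes are taken together and neither change accounts for it alone.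

These compounds leave open whether anything other than a methyl on this aromatic carbon, such as a longer chain, an amine or a carboxylic acid, would move the number beyond the scatter. No independent information is available that could explain these readings.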